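This account rests on a few compounds, and the source may have more. Where it says the series, first, only, none or still open, it means among the compounds named here.

Compound 2 `COc1cccc(CCCCCCC(=O)N2CCCC2)c1` carries a methoxy group on its aromatic ring. In an assay on HEK293 cells for inhibition of N-acylethanolamine-hydrolyzing acid amidase (Rattus norvegicus), read by LC-MS, with a stated time of 30 min (a lower number here means a stronger inhibitor, a higher number a weaker inhibitor), compound 2 gives > 100000 nM, which is a limit of the assay and not a measured number. Within the data shown here, compound 1 `Cc1cccc(CCCCCCC(=O)N2CCCC2)c1`, with a methyl in that position, is the only other compound measured here; in this assay compound 1 gives 8300 nM. Among the measured compounds shown here, the one measured step, an at least 12-fold higher number from compound 1 to compound 2 (1.08 log units; beyond the scatter), is large and runs toward weaker inhibition, and it ends at the limit described as the limit of > 100000 nM in this assay, at which 1 of the 2 values shown sits. Compound 3 `O=C(O)c1cccc(CCCCCCC(=O)N2CCCC2)c1` is not yet measured. It differs from compound 2 by carboxy in place of methoxy on an aromatic carbon. For the measured compounds named here, no measured step exchanges a methoxy for a carboxy, so the only guidance is that compound 2 already sits at the limit, and the measured step from compound 1 to compound 2 gives no direction for the next exchange. The number for compound 3 is therefore expected to stay near that limit, with a number no higher from compound 2 to compound 3 (the limit leaves the size open) estimated as no clear change beyond the scatter. The estimate for compound 3 is 100000 nM, within a range from 20000 nM to 500000 nM.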

Compound 3, half-maximal inhibitory concentration: > 100000 nM
Compound 3 was reported as a limit; the forecaster's own chance of this, stated with the estimate: 65%; the middle value sits exactly at the limit.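

Carboxy in place of methyl on this aromatic carbon gives an at least 12-fold higher number from compound 1 to compound 3 (1.08 log units; beyond the scatter), so methoxy is no longer the only replacement for the methyl that ends far from the value of compound 1. The two replacements differ in what they add: carboxy is one heavy atom larger than methoxy and brings a hydrogen-bond donor, yet in this assay neither brings a measurable value, and among the three compounds shown only the methyl compound gives one. The value of compound 3 is a limit and not a number, as is that of compound 2, so the step between them cannot be read, and either could be the weaker inhibitor: the limit of > 100000 nM in this assay, at which 2 of the 3 values shown sit.

With only these three groups at this place, nothing separates the effect of size from that of the oxygen atoms, and the data give no cause for the loss. On these data alone, whether a small group without oxygen, such as ethyl or chlorine, or a group with nitrogen, such as an amine, would keep a measurable value at this position remains open.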